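This account rests on a few compounds, and the source may have more. Where it says the series, first, only, none or still open, it means among the compounds named here.

Measured so far in an assay on isolated protein for inhibition of Rho-associated protein kinase 2 (Homo sapiens), read by radiometric assay and 33P incorporation, with a stated time of 40 min, in the presence of a further agent that is not named here; on this read-out higher numbers stand for weaker inhibition and lower numbers for stronger inhibition:
compound 1 `COc1cccc(Cn2cnc3sc(-c4ccc5[nH]ncc5c4)cc3c2=O)c1` — 2 nM
compound 2 `COc1cccc(Cn2cnc3sc(-c4cccnc4)cc3c2=O)c1` — 3480 nM

Compound 1 holds the lowest of the two numbers in this assay. Among the measured compounds shown here, the nearest measured neighbour is compound 2, and the only measured step in the set is a 1700-fold higher number from compound 1 to compound 2 (3.24 log units; beyond the scatter); it replaces the indazolyl group with a plain pyridyl group on the same carbon of the shared core.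

Compound 3 `COc1cccc(Cn2cnc3sc(-c4ccnc(OC)c4)cc3c2=O)c1` is not yet measured. It differs from compound 1 as follows: 2-methoxypyridin-4-yl in place of 1H-indazol-5-yl on an aromatic carbon

The step from compound 1 to compound 2 is the one that bears on this change: both exchanges remove the same indazolyl group from the same position of the core and put a single six-membered heteroaryl ring in its place. That step was large and beyond the scatter. A step of comparable size and in the same direction is therefore expected for compound 3, with wide uncertainty since the entering ring also carries a methoxy group and a differently placed ring nitrogen, for which no measured comparison exists.

Compound 3 is estimated at 1500 nM in this assay, within a range of 200 nM to 10000 nM, which corresponds to an expected step of a 750-fold higher number from compound 1 to compound 3 (2.88 log units; beyond the scatter).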

Compound 3, half-maximal inhibitory concentration: 6920 nM
Compound 3: the middle estimate sits 4.6-fold (0.66 log units) below what was measured; low and high end bracket the measured number.
By their numbers in this assay, from the lowest: compound 1; then compounds 2 and 3 (each within the scatter of the next).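

In this assay, the large rise on leaving 1H-indazol-5-yl on the aromatic carbon next to the ring sulfur now appears with a second entering ring, as a 3500-fold higher number from compound 1 to compound 3 (3.54 log units; beyond the scatter) shows. The two single-ring replacements cannot be separated, since a 2.0-fold higher number from compound 2 to compound 3 (0.30 log units; within the scatter) leaves 2-methoxypyridin-4-yl and pyridin-3-yl level, so the methoxy group and the different ring-nitrogen placement together bring no recovery at this position. Among the three compounds, the low number therefore stays with compound 1, the only one carrying the fused 1H-indazol-5-yl group, although three compounds cannot show which feature of that group matters. Nothing measured here gives a reason for the size of these steps.

Still open, on these data alone, is whether the fused ring or the indazole ring-nitrogen hydrogen carries the effect, which an indole or an indazole with a methyl on that nitrogen would help to separate. Also open, as far as these compounds go, is whether any single six-membered ring can come closer to compound 1, for instance a pyridine carrying an amine or an amide.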